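The source may hold more compounds than are shown below. What is called first, only, known or untested is meant among the compounds shown, and "the series" means these compounds.

Measured in a physicochemical assay for solubility, with a stated time of 24 h, at pH 2.2 (on this read-out higher numbers stand for higher solubility and lower numbers for lower solubility), so far:
- compound 1 `O=C(NC[C@@H]1[C@H]2CN(C(=O)/C=C/c3cc(Cl)cc(Cl)c3)C[C@@H]12)c1ccc2[nH]c(=O)oc2c1` gives < 1 ug/mL as a limit
- compound 2 `O=C(NC[C@@H]1[C@H]2CN(C(=O)C3CC3c3cc(Cl)cc(Cl)c3)C[C@@H]12)c1ccc2[nH]c(=O)oc2c1` gives < 1 ug/mL as a limit
- compound 3 `CC(OC(=O)N1C[C@@H]2[C@@H](CNC(=O)c3ccc4[nH]c(=O)oc4c3)[C@@H]2C1)c1cc(Cl)cc(Cl)c1` gives < 1 ug/mL as a limit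

Compound 3 has a limit and not a number, a position it shares with the others: the limit of < 1 ug/mL in this assay, at which 3 of the 3 values shown sit.

Compound 4 `Cc1ccc(COC(=O)N2C[C@@H]3[C@@H](CNC(=O)c4ccc5[nH]c(=O)oc5c4)[C@@H]3C2)nc1` carries (5-methylpyridin-2-yl)methyl on an oxygen next to a carbonyl group: a group of 8 heavy atoms (7 carbon, 1 nitrogen; one six-membered aromatic ring with 1 hetero atom) in place of a group of 10 heavy atoms (8 carbon, 2 chlorine; one six-membered aromatic ring of carbon only), on an oxygen next to a carbonyl group.

Going by the values given here, three measured steps bear on this change: a step that the two limits leave unreadable from compound 1 to compound 2, a step that the two limits leave unreadable from compound 1 to compound 3 and a step that the two limits leave unreadable from compound 2 to compound 3. None has a readable size, and all three compounds keep their chlorine atoms, so the expectation rests on the structural change alone. With chlorine leaving and a ring with a hetero atom entering, a rise in this assay is expected, estimated as an at least 25-fold higher number from compound 3 to compound 4 (1.39 log units; beyond the scatter). For compound 4 the estimate is 25 ug/mL, with an expected range from 3 ug/mL to 150 ug/mL.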

Compound 4, solubility: > 92 ug/mL
Compound 4 was reported as a limit; the forecaster's own chance of this, stated with the estimate: 15%; middle value at least 3.6-fold (0.56 log units) away from the limit.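

In this assay, (5-methylpyridin-2-yl)methyl on an oxygen next to a carbonyl group gives a readable step, where all earlier steps could not be read: an at least 92-fold higher number from compound 3 to compound 4 (1.96 log units; beyond the scatter). The changes that also replace the carbonyl-bearing link give equally readable steps, an at least 92-fold higher number from compound 2 to compound 4 (1.96 log units; beyond the scatter) and an at least 92-fold higher number from compound 1 to compound 4 (1.96 log units; beyond the scatter). Compound 4 has a limit of the assay and not a number: the limit of > 92 ug/mL in this assay, at which 1 of the 4 values shown sits.

From the compounds shown here alone, how far compound 4 lies past that limit remains open. Also open, going by these compounds, is whether losing the chlorines, adding the ring nitrogen or adding the methyl matters most, which a plain benzyl group or a 5-chloropyridin-2-ylmethyl group could help separate.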